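Aryl Amide in Place of Cyclopentyl Amide, Toxicity Check

The source may report more compounds than this note shows. Statements on the series, on what has been measured and on what is new or still open speak of the compounds shown alone.

Two compounds sharing an amide-linked core have been assessed in a toxicity assay on THP-1 cells (Homo sapiens) for inhibition; on this read-out higher numbers stand for lower toxicity in this test and lower numbers for higher toxicity in this test. Compound 1 `Cn1c(-c2cccc(C#N)c2)cnc1NC(=O)c1ncc[nH]1` carries a nitrile-bearing aryl group on the core. In this assay compound 1 reaches only a limit, > 50000 nM, which is the limit of > 50000 nM in this assay, at which 1 of the 2 values shown sits. Compound 2 `COc1ccc(-c2cnc(NC(=O)C3CCCC3)n2C)cc1` carries a 4-methoxyphenyl on the core and a cyclopentyl on the carbonyl carbon. In this assay compound 2 likewise gives only a limit, > 100000 nM, which is the limit of > 100000 nM in this assay, at which 1 of the 2 values shown sits. For the measured compounds named here, both results therefore sit at the ceiling of this test, and no step between measured compounds can be drawn from them.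

Compound 3 `COc1ccc(C(=O)Nc2ncc(-c3ccc(OC)cc3)n2C)cc1` has not yet been measured. It differs from compound 2 in one place: 4-methoxyphenyl in place of cyclopentyl on a carbonyl carbon. Going by the values given here, no measured step exists here to lean on, so the shift expected in this assay is a number no higher from compound 2 to compound 3 (the limit leaves the size open), which is meant as nothing beyond the usual scatter. Compound 3 is accordingly estimated in this assay at 100000 nM, within 30000 nM to 300000 nM, most likely reported once more as a limit rather than as a number.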

Compound 3, half-maximal cytotoxic concentration: > 100000 nM
Compound 3: no number, only a limit; the forecaster's own chance of this, stated with the estimate: 80%; the middle value lies on the limit itself.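

Compound 2 and compound 3 both end at a limit in this assay, and no step can be read between them. The compounds shown leave open what number each of them would give in this assay, and whether 4-methoxyphenyl in place of cyclopentyl on a carbonyl carbon changes this read-out at all.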